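The compounds below may be only part of what the source reports. "The series", "measured", "known", "first", "only" and "open" are said of these compounds alone.

Working notes on the series. Among the compounds with values here, compound 2 `CCc1nc(-c2ccc(OC)cc2O)c(CC)nc1NC(CC)CC` gives 1180 nM in an assay on IMR-32 cells for displacement of a labelled ligand from corticotropin-releasing factor receptor 1 (Homo sapiens), read by scintillation counting, with a stated time of 2 h (on this read-out higher numbers stand for weaker inhibition and lower numbers for stronger inhibition), the highest of the two numbers measured so far; the nearest is compound 1 `CCc1nc(-c2ccc(OC)cc2OC(F)(F)F)c(CC)nc1NC(CC)CC` at 4.1 nM. Within the data shown here, the single measured step, a 290-fold higher number from compound 1 to compound 2 (2.46 log units; beyond the scatter), is large. Compound 3 `CCc1nc(-c2ccc(OC)cc2C(F)(F)F)c(CC)nc1NC(CC)CC` carries trifluoromethyl in place of hydroxy on an aromatic carbon. This change runs against the direction of the measured step, so a large downward step in this assay is expected, roughly of the size seen for a 290-fold higher number from compound 1 to compound 2 (2.46 log units; beyond the scatter) but reversed. Compound 3 is therefore estimated at 10 nM, within 2 nM to 60 nM. The expected step is a 120-fold lower number from compound 2 to compound 3 (2.07 log units; beyond the scatter).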

Compound 3, inhibition constant: 4.4 nM
Compound 3: the middle estimate sits 2.3-fold (0.36 log units) above what was measured; measured number inside the range.
By their numbers in this assay, from the lowest: compounds 1 and 3 (each within the scatter of the next); then compound 2.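

At this aromatic carbon, ortho to a large group, trifluoromethyl in place of hydroxy gives a 270-fold lower number from compound 2 to compound 3 (2.43 log units; beyond the scatter) in this assay, so the step seen earlier is recovered without the oxygen. Trifluoromethoxy and trifluoromethyl are not told apart, with a 1.1-fold higher number from compound 1 to compound 3 (0.03 log units; within the scatter), and among the three groups shown only hydroxy stands off from the others. Nothing available accounts for the gap between hydroxy and the two fluorinated groups. Open, going by these compounds, is whether fluorine is needed here at all, as a methyl or a chlorine at this carbon would show. Also open, on these data alone, is whether an amine here would track hydroxy.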